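This account rests on a few compounds, and the source may have more. Where it says the series, first, only, none or still open, it means among the compounds named here.

- compound 1 `CC(C)N1CCC(c2ccc3c(c2)oc(=O)n3C(=O)NCCCCc2ccccc2)CC1` at 0.667 h
- compound 2 `CN1CCN(c2ccc3c(c2)oc(=O)n3C(=O)NCCCCc2ccccc2)C(=O)C1` at 0.333 h

Within the data shown here, in an ADME assay on a cell-free system (plasma, Mus musculus) for metabolic stability, read by LC-MS, tested at 2 uM (on this read-out lower numbers stand for a shorter-lived compound and higher numbers for a longer-lived compound), compound 2 has only one neighbour to stand against. Among the measured compounds shown here, the single measured step of a 2.0-fold lower number from compound 1 to compound 2 (0.30 log units; within the scatter) stays within the scatter and falls on an aromatic carbon, so the two numbers do not separate. For the measured compounds named here, compound 3 `CN1CCN(c2ccc3c(c2)oc(=O)n3C(=O)NCCCCc2ccccc2)CC1` carries 4-methylpiperazin-1-yl in place of 4-methyl-2-oxopiperazin-1-yl on an aromatic carbon and has no measured step of its own. That one step gives no ground to expect a change beyond the scatter in this assay for this replacement. The expected step of a 1.5-fold higher number from compound 2 to compound 3 (0.18 log units; within the scatter) stays inside the scatter. Compound 3 is estimated at 0.5 h with a range of 0.2 h to 1.2 h on this read-out.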

Compound 3, half-life: < 0.0834 h
Compound 3: no number, only a limit; the forecaster's own chance of this, stated with the estimate: 5%; middle value at least 5.9-fold (0.77 log units) from the limit.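

In this assay, among these compounds, the 4-methyl-2-oxopiperazin-1-yl to 4-methylpiperazin-1-yl change on this aromatic carbon gives the first step at this position beyond the scatter: an at least 3.9-fold lower number from compound 2 to compound 3 (0.60 log units; beyond the scatter). The replacement of 1-isopropylpiperidin-4-yl by 4-methylpiperazin-1-yl also goes beyond it, as an at least 7.9-fold lower number from compound 1 to compound 3 (0.90 log units; beyond the scatter). The reading for compound 3 is a limit and not a number, so both steps give only a minimum size: the limit of < 0.0834 h in this assay, at which 1 of the 3 values shown sits.

The full size of these steps remains open, as does what lies behind them. Also open, on these data alone, is whether a morpholine or an N-acetylpiperazine on this carbon would track compound 2 or compound 3.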